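Swapping bromo for methyl: what compound 3 may show

The source may hold more compounds than are shown below. What is called first, only, known or untested is meant among the compounds shown, and "the series" means these compounds.

The series rests on a shared core, shown in compound 1 `O=C(CN1CCN(C(=O)c2ccccc2)CC1)N1CCN(CCCc2c[nH]c3ccccc23)CC1` and compound 2 `O=C(CN1CCN(C(=O)c2ccc(Br)cc2)CC1)N1CCN(CCCc2c[nH]c3ccccc23)CC1`. In an ADME assay on HEK293 cells (Homo sapiens) for cytotoxicity, read by MTT assay, with a stated time of 72 h (a lower number here means a stronger inhibitor, a higher number a weaker inhibitor), compound 1 gives > 200000 nM, and this is a limit of the assay rather than a number. Within the data shown here, compound 2 gives 71900 nM, the only actual number measured so far in this assay.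

Compound 3 `Cc1ccc(C(=O)N2CCN(CC(=O)N3CCN(CCCc4c[nH]c5ccccc45)CC3)CC2)cc1` departs from compound 2 at a single place: methyl in place of bromo on an aromatic carbon. In plain terms, the bromo of compound 2 gives way to a methyl at that same place, para to a large group.

Among the measured compounds shown here, only one measured step bears on this change: an at least 2.7-fold lower number from compound 1 to compound 2 (0.44 log units; beyond the scatter), in which bromo took the place of hydrogen on an aromatic carbon. Compound 3 gives up that bromo but does not return to hydrogen, so part of the step of an at least 2.7-fold lower number from compound 1 to compound 2 (0.44 log units; beyond the scatter) is expected to be lost. The expected change is modest and toward a higher number, with an estimated size of a 2.1-fold higher number from compound 2 to compound 3 (0.32 log units; beyond the scatter). This rests on a single step, so the expectation is loose. For compound 3 the estimated value is 150000 nM, with an expected range of 70000 nM to 200000 nM.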

Compound 3, half-maximal inhibitory concentration: 159000 nM
Beside the measured number, compound 3's estimate is 1.1-fold (0.03 log units) below it; measured number inside the range.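

In this assay, bromo and methyl on the same aromatic carbon are not interchangeable, since the swap gives a 2.2-fold higher number from compound 2 to compound 3 (0.34 log units; beyond the scatter). Set against hydrogen, methyl gives an at least 1.2-fold lower number from compound 1 to compound 3 (0.09 log units; that floor lies within the scatter), so the data do not separate methyl from hydrogen at this place, and among the three compounds only the bromo of compound 2 is shown to bring a lower number beyond the scatter. That comparison with hydrogen remains open-ended because compound 1 is held by a limit of the assay rather than a number: the limit of > 200000 nM in this assay, at which 1 of the 3 values shown sits.

The compounds shown leave open whether the lower number belongs to bromo alone or would also appear with another halogen such as chloro or fluoro at this place, para to a large group. They also leave open what a methoxy group, an amine or a carboxylic acid would do there, and how far hydrogen and methyl truly lie apart, given that one of the two values is only a limit.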